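Amide to Ester on the Shared Core of Compound 2

A few compounds are considered here, and "the series" means these few. Any claim that something is new, unique, unknown or untested is made for them only; others in the source may bear on it.

Of the compounds shown here, two have been measured so far. Compound 1 `CCOC(=O)NC(=O)NC1=CS(=O)(=O)O[C@@]12[C@@H](CO[Si](C)(C)C(C)(C)C)O[C@@H](n1cc(C)c(=O)n(C)c1=O)[C@@H]2O[Si](C)(C)C(C)(C)C` gives 14000 nM in a functional assay on HEL cells (Homo sapiens) (a lower number here means that less compound is tolerated, a higher number that more compound is tolerated), and compound 2 `Cc1cn([C@@H]2O[C@H](CO[Si](C)(C)C(C)(C)C)[C@@]3(OS(=O)(=O)C=C3NCCC(N)=O)[C@H]2O[Si](C)(C)C(C)(C)C)c(=O)n(C)c1=O` gives 14800 nM. Within the data shown here, the single step between them, a 1.1-fold higher number from compound 1 to compound 2 (0.02 log units; within the scatter), changes nothing that the scatter would not cover. Compound 2 thus stands at the higher of the two numbers, but its distance to compound 1 is within the scatter, so no order between them can be read.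

Compound 3 `COC(=O)CCNC1=CS(=O)(=O)O[C@@]12[C@@H](CO[Si](C)(C)C(C)(C)C)O[C@@H](n1cc(C)c(=O)n(C)c1=O)[C@@H]2O[Si](C)(C)C(C)(C)C` differs from compound 2 by methoxy in place of amino on a carbonyl carbon. Among the measured compounds shown here, no measured step touches this change; the one step known concerns another part of the chain and was itself within the scatter. With only this to go on, the step of a 1.0-fold higher number from compound 2 to compound 3 (0.01 log units; within the scatter) is expected to stay within the scatter. Compound 3 is therefore estimated at 15000 nM, with a range from 7000 nM to 32000 nM.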

Compound 3, half-maximal cytotoxic concentration: 94000 nM
Estimate against measurement, compound 3: 6.3-fold (0.80 log units) below; the whole stated range lies below it.
By their numbers in this assay, from the lowest: compounds 1 and 2 (each within the scatter of the next); then compound 3.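

In this assay, among these compounds, the far end of the chain on the amine nitrogen proves to matter: methoxy in place of amino on a carbonyl carbon gives a 6.4-fold higher number from compound 2 to compound 3 (0.80 log units; beyond the scatter) and is the first change here to go beyond the scatter. Placing 2-(methoxycarbonyl)ethyl instead of (ethoxycarbonyl)carbamoyl on the amine nitrogen gives a 6.7-fold higher number from compound 1 to compound 3 (0.83 log units; beyond the scatter), while 2-carbamoylethyl in that place stayed within the scatter, so of these three groups only 2-(methoxycarbonyl)ethyl stands apart. Nothing available explains this shift.

As far as these compounds go, whether a carboxylic acid or an ethyl ester at this carbonyl carbon would give a number like that of compound 3 remains open. So does the effect of a longer chain carrying the same methyl ester.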